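The source may report more compounds than this note shows. Statements on the series, on what has been measured and on what is new or still open speak of the compounds shown alone.

Working notes on a small set of nucleoside analogues tested in a functional assay on HeLa S3 cells (Homo sapiens) for antiproliferative activity, read by XTT assay, with a stated time of 72 h; on this read-out lower numbers stand for stronger inhibition and higher numbers for weaker inhibition.

Compound 1, `O=c1[nH]cnc2c1c(-c1cccs1)cn2[C@@H]1O[C@H](CO)[C@@H](O)[C@H]1O`, carries a thiophen-2-yl group on the shared core. In this assay compound 1 gives only a limit, > 20000 nM. Compound 2, `O=c1[nH]cnc2c1c(-c1ccsc1)cn2[C@@H]1O[C@H](CO)[C@@H](O)[C@H]1O`, differs from it by thiophen-3-yl in place of thiophen-2-yl on an aromatic carbon. In this assay compound 2 likewise gives only a limit, > 20000 nM. The step from compound 1 to compound 2 is therefore a step that the two limits leave unreadable from compound 1 to compound 2.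

Compound 3, `CNc1ncnc2c1c(-c1cccs1)cn2[C@@H]1O[C@H](CO)[C@@H](O)[C@H]1O`, has a different core from compound 1; the difference between the two cores is not broken down here. In this assay compound 3 also gives only a limit, > 20000 nM. Within the data shown here, all three values so far sit at the same limit, as summarised by the limit of > 20000 nM in this assay, at which 3 of the 3 values shown sit.

Compound 4, `CNc1ncnc2c1c(-c1ccsc1)cn2[C@@H]1O[C@H](CO)[C@@H](O)[C@H]1O`, is still to be measured in this assay. It differs from compound 3 by thiophen-3-yl in place of thiophen-2-yl on an aromatic carbon, the same change as that from compound 1 to compound 2, made at the same place on the core. For compound 4 the step from compound 3 is expected to be a step that the limit leaves unreadable from compound 3 to compound 4, because compound 1 with > 20000 nM and compound 2 with > 20000 nM both sit at the limit and the same change gave no readable shift there. Compound 4 is accordingly expected to come out at about 30000 nM, most likely reported as a limit again, within a range of 15000 nM to 100000 nM.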

Compound 4, half-maximal inhibitory concentration: > 20000 nM
Compound 4: a limit, no number (the forecaster's own chance of this, stated with the estimate: 85%); the middle value lies beyond the limit too.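

In this assay compound 4 gives > 20000 nM, which is a limit and not a number. Compound 3 also gives only a limit, so no step between compound 3 and compound 4 can be read, and the series stays at one ceiling: the limit of > 20000 nM in this assay, at which 4 of the 4 values shown sit.

The compounds shown leave open whether thiophen-2-yl and thiophen-3-yl, or the two cores, differ at all in this assay.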